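A propanoyl group on the ring nitrogen of compound 1

The source may report more compounds than this note shows. Statements on the series, on what has been measured and on what is new or still open speak of the compounds shown alone.

Values measured so far in a functional assay on NCI-H460 cells (Homo sapiens) for cytotoxicity, read by MTT assay, with a stated time of 72 h; a higher number here means a weaker inhibitor, a lower number a stronger inhibitor:
- compound 1 `COc1cc(/C=C2\CNC/C(=C\c3cc(OC)c(OC)c(OC)c3)C2=O)cc(OC)c1OC` gives 1500 nM
- compound 2 `COc1ccc(/C=C2\CN(C)C/C(=C\c3ccc(OC)c(OC)c3)C2=O)cc1OC` gives 3100 nM

Compound 1 holds the lower of the two numbers, and compound 2 stands above it by more than the usual scatter. Going by the values given here, no two measured compounds differ in one place only, so the data offer no single-change step to lean on.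

Compound 3 `CCC(=O)N1C/C(=C\c2cc(OC)c(OC)c(OC)c2)C(=O)/C(=C/c2cc(OC)c(OC)c(OC)c2)C1` keeps the core of compound 1 and carries propanoyl in place of hydrogen on an amine nitrogen in a ring, a change counted as propanoyl in place of hydrogen on an amine nitrogen in a ring in full. Without a measured precedent, the expectation in this assay is tentative: a modest move toward a lower number, meaning a stronger inhibitor, and a result within the scatter would remain possible. The estimated change is a 2.1-fold lower number from compound 1 to compound 3 (0.33 log units; beyond the scatter) in size. For compound 3 the expected value is 700 nM with 200 nM to 2500 nM as its estimated range.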

Compound 3, half-maximal inhibitory concentration: 2700 nM
Compound 3: middle estimate off by 3.9-fold (0.59 log units), on the low side; the whole stated range lies below it.
By their numbers in this assay, from the lowest: compounds 1, 3 and 2 (each within the scatter of the next, the first and the last beyond it).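

In this assay, putting propanoyl in place of hydrogen on an amine nitrogen in a ring gives a 1.8-fold higher number from compound 1 to compound 3 (0.26 log units; within the scatter). Going by these compounds alone, this is the first single-place comparison, and it shows that, at least for this pair, the hydrogen on this nitrogen can give way to propanoyl without a difference beyond the scatter. No independent measurement bears on this result.

As far as these compounds go, a single acyl group cannot show how far this holds, so it remains open whether a shorter acetyl group, a larger benzoyl group or a longer chain ending in a carboxylic acid would leave the number where it is. An amine carried on a chain at this nitrogen is equally untested among the compounds shown, and compound 2 differs from both others in more than one place, so it cannot settle the point.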